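Swapping the polar group on the benzylic chain carbon

This account rests on a few compounds, and the source may have more. Where it says the series, first, only, none or still open, it means among the compounds named here.

Three compounds share one core and differ at the far end of the biphenyl arm. Compound 1 `O=C(O)CC/C=C\CO[C@H]1C(OCc2ccc(-c3ccccc3)cc2)CC[C@@H]1N1CCCCCC1` carries only hydrogen there and in a functional assay for antagonist activity at thromboxane A2 receptor (Rattus norvegicus) (on this read-out lower numbers stand for tighter binding and higher numbers for weaker binding), compound 1 gives 25.1 nM. Compound 2 `CC(=O)NCc1ccccc1-c1ccc(COC2CC[C@H](N3CCCCCC3)[C@H]2OC/C=C\CCC(=O)O)cc1` gives 126 nM, and compound 3 `NC(=O)Cc1ccccc1-c1ccc(COC2CC[C@H](N3CCCCCC3)[C@H]2OC/C=C\CCC(=O)O)cc1` gives 158 nM; compound 3 thus has the highest number of the three, though its gap to compound 2 is within the scatter, and only its gap to compound 1 is clear, as the step of a 6.3-fold higher number from compound 1 to compound 3 (0.80 log units; beyond the scatter) shows. Compound 4 `O=C(O)CC/C=C\CO[C@H]1C(OCc2ccc(-c3ccccc3CCO)cc2)CC[C@@H]1N1CCCCCC1` differs from compound 3 by hydroxymethyl in place of carbamoyl on a saturated chain carbon bound to an aromatic carbon. The step that bears most directly on this is a 1.3-fold higher number from compound 2 to compound 3 (0.10 log units; within the scatter), an exchange of one polar group for another at the same chain carbon that left the number essentially unchanged. The steps of a 5.0-fold higher number from compound 1 to compound 2 (0.70 log units; beyond the scatter) and a 6.3-fold higher number from compound 1 to compound 3 (0.80 log units; beyond the scatter) say that adding any such group to the bare arm costs a modest amount. On that basis only a small step is expected for a 1.4-fold lower number from compound 3 to compound 4 (0.16 log units; within the scatter) in this assay, with no clear direction. Compound 4 is therefore estimated at 110 nM, within 40 nM to 300 nM.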

Compound 4, dissociation constant: 31.6 nM
The estimate for compound 4 lay 3.5-fold (0.54 log units) above the measured number; the measured number lies below the stated range.
By their numbers in this assay, from the lowest: compounds 1 and 4 (each within the scatter of the next); then compounds 2 and 3 (each within the scatter of the next).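

On the saturated chain carbon bound to an aromatic carbon, the group carried there matters in this assay: hydroxymethyl in place of carbamoyl gives a 5.0-fold lower number from compound 3 to compound 4 (0.70 log units; beyond the scatter), and hydroxymethyl in place of acetamido gives a 4.0-fold lower number from compound 2 to compound 4 (0.60 log units; beyond the scatter). Adding a group to the bare arm therefore does not always carry a cost, since 2-hydroxyethyl in place of hydrogen gives only a 1.3-fold higher number from compound 1 to compound 4 (0.10 log units; within the scatter), whereas the carbamoylmethyl and acetamidomethyl groups of compound 3 and compound 2 both cost a modest amount. No measurement at hand accounts for this difference between the groups.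

Still open, on these data alone, is whether a 2-aminoethyl group or a longer hydroxyalkyl chain at this place would also stay level with compound 1. Going by these compounds alone, with compound 4 as the only hydroxyl-bearing example, the result cannot yet be extended to other groups.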